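A Halogen Shift on the Phenyl Ring of Compound 3

A few compounds are considered here, and "the series" means these few. Any claim that something is new, unique, unknown or untested is made for them only; others in the source may bear on it.

Of the compounds shown here, three have been measured in an assay on cells for inhibition of sodium- and chloride-dependent glycine transporter 1 (Homo sapiens); on this read-out higher numbers stand for an effect only at larger amounts of compound and lower numbers for an effect already at smaller amounts. Compound 3, with the structure `COc1cc(C(F)(F)F)cc(SC)c1C(=O)NC1(c2ccc(F)cc2)CCCN(C)C1`, gives 26 nM. This is the second highest of the three numbers. Compound 1, with the structure `COc1cc(C(F)(F)F)cc(SC)c1C(=O)N[C@@]1(c2ccccc2)CCCN(C)C1`, gives 10 nM, a lower number than compound 3 by a gap beyond the scatter. Compound 2, with the structure `CN1CCCC(NC(=O)c2ccc(Cl)cc2Cl)(c2ccccc2)C1`, gives 670 nM, a much higher number than compound 3, far beyond the scatter.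

Compound 4, with the structure `COc1cc(C(F)(F)F)cc(SC)c1C(=O)NC1(c2cccc(Cl)c2)CCCN(C)C1`, has not yet been measured. It differs from compound 3 in one place: 3-chlorophenyl in place of 4-fluorophenyl on a saturated ring carbon. Among the measured compounds shown here, no measured pair in this set shows the same change, so nothing here tells how large a step this change brings on its own. The expected step of a 1.3-fold higher number from compound 3 to compound 4 (0.13 log units; within the scatter) is small, in the direction of a somewhat higher number, and not clearly beyond the scatter. For compound 4 the expected value in this assay is estimated at 35 nM, with a range from 12 nM to 110 nM.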

Compound 4, half-maximal effective concentration: 25 nM
Estimate against measurement, compound 4: 1.4-fold (0.15 log units) above; the range from low to high includes it.
By their numbers in this assay, from the lowest: compound 1; then compounds 4 and 3 (each within the scatter of the next); then compound 2.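

In this assay, putting 3-chlorophenyl in place of 4-fluorophenyl on the saturated ring carbon gives a 1.0-fold lower number from compound 3 to compound 4 (0.02 log units; within the scatter), so compound 3 and compound 4 cannot be told apart on this read-out. Among the compounds shown here, this is the first direct look at this position: for this pair, with the rest of the structure held the same, the change of halogen and its new place on the phenyl ring together leave the number within the usual scatter. Since both features change at once, the pair cannot show what each does alone, and two separate effects that cancel each other cannot be ruled out. Nothing measured here explains the result. From the compounds shown here alone, whether the position accepts equally well a phenyl ring carrying an amine or a carboxylic acid stays open. So does the outcome when a longer chain stands in place of the halogen.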